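Replacing an Amino Group with an Amide on a Coumarin-like Core

The source may report more compounds than this note shows. Statements on the series, on what has been measured and on what is new or still open speak of the compounds shown alone.

Of the compounds shown here, two sharing one core have been tested in a functional assay on MDA-MB-231 cells (Homo sapiens) for inhibition, read by MTT assay, with a stated time of 48 h; on this read-out lower numbers stand for stronger inhibition and higher numbers for weaker inhibition. Compound 1 `COc1cc2cc(C(=O)NCc3ccc(F)cc3)c(=O)oc2cc1OCCCOc1no[n+]([O-])c1S(=O)(=O)c1ccccc1` gives 770 nM. Compound 2 `COc1cc2cc(N)c(=O)oc2cc1OCCCOc1no[n+]([O-])c1S(=O)(=O)c1ccccc1`, which carries an amino group in place of the larger amide, gives 1390 nM. Among the two numbers, compound 2 stands highest, but the gap is small: the change was a 1.8-fold higher number from compound 1 to compound 2 (0.26 log units; within the scatter).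

Compound 3 `COc1cc2cc(C(=O)Nc3ccc(F)cc3)c(=O)oc2cc1OCCCOc1no[n+]([O-])c1S(=O)(=O)c1ccccc1` is the next member, and it differs from compound 2 in one place: (4-fluorophenyl)carbamoyl in place of amino on an aromatic carbon. Among the measured compounds shown here, this brings back an amide close in kind to the one in compound 1, with the aromatic ring now attached directly to the amide nitrogen rather than through one extra carbon.

For the measured compounds named here, only one step bears on this change, the one from compound 1 to compound 2, and it stayed within the scatter. With the amide restored, compound 3 is therefore expected to land near compound 1, giving a step of a 1.7-fold lower number from compound 2 to compound 3 (0.24 log units; within the scatter), which is not beyond the scatter. The expected value for compound 3 in this assay is 800 nM, with a range from 350 nM to 1800 nM.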

Compound 3, half-maximal inhibitory concentration: 1200 nM
Beside the measured number, compound 3's estimate is 1.5-fold (0.18 log units) below it; the measured number falls inside the stated range.
By their numbers in this assay, from the lowest: compounds 1, 3 and 2 (each within the scatter of the next).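

Swapping the amino group for the amide gives a 1.2-fold lower number from compound 2 to compound 3 (0.06 log units; within the scatter), so in this assay the position carries either the small amino group or the larger amide with the two numbers staying within the scatter of each other. Comparing the two amides, 4-fluorophenyl in place of 4-fluorobenzyl on the amide-type nitrogen gives a 1.6-fold higher number from compound 1 to compound 3 (0.19 log units; within the scatter), so this read-out does not tell these two groups apart, and all three compounds sit within the scatter of their neighbours. The data shown offer no explanation for how close the three numbers stay.

The compounds shown leave open whether a group of another kind at this carbon, such as a carboxylic acid or a methyl ester, or a longer chain on the amide nitrogen, such as 2-(4-fluorophenyl)ethyl, would also stay within the scatter. They also leave open what the fluorine contributes, as both amides carry it and a plain phenyl ring is absent from this set, and what happens when the rest of the molecule, identical in all three, is changed.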